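The source may hold more compounds than are shown below. What is called first, only, known or untested is meant among the compounds shown, and "the series" means these compounds.

Measured so far:
- compound 1 `CCCc1cccc(N2CCNCC2)n1` — 10 mg/kg
- compound 2 `c1ccc(CCc2cccc(N3CCNCC3)n2)cc1` — > 300 mg/kg
- compound 3 `CCCCCCCCCc1cccc(N2CCNCC2)n1` — 10 mg/kg

In a functional assay on the whole organism with Mus musculus as the target, in the maximal electroshock model, with a stated time of 120 min (a lower number here means that less compound is needed, a higher number that more compound is needed for the effect), compound 1 stands level with compound 3, no change at the digits printed from compound 1 to compound 3 (within the scatter). The value of compound 2 is a limit of the assay, not a number (the limit of > 300 mg/kg in this assay, at which 1 of the 3 values shown sits). The step is large: an at least 30-fold higher number from compound 1 to compound 2 (1.47 log units; beyond the scatter); likewise an at least 30-fold lower number from compound 2 to compound 3 (1.47 log units; beyond the scatter).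

Compound 4 `CC(C)(C)c1cccc(N2CCNCC2)n1` differs from compound 1 as follows: tert-butyl in place of propyl on an aromatic carbon. Going by the values given here, two steps bear on it. The step with a phenyl entering on the chain was large, but tert-butyl brings no ring, so that step is a poor guide. The step with hexyl entering, no ring, stayed within the scatter. No step beyond the scatter is therefore expected, and the estimate for compound 4 is 10 mg/kg (5 mg/kg to 30 mg/kg), so that the expected step is no change at the digits printed from compound 1 to compound 4 (within the scatter).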

Compound 4, minimum effective dose: > 300 mg/kg
Compound 4: only a limit was reported (the forecaster's own chance of this, stated with the estimate: 10%); at least 30-fold (1.47 log units) between middle value and limit.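

Tert-butyl in place of propyl on this aromatic carbon, next to the ring nitrogen, gives an at least 30-fold higher number from compound 1 to compound 4 (1.47 log units; beyond the scatter), so a large step here does not need an entering ring, which compound 2 alone could not show. Compound 3 stays level with compound 1 at the digits printed, so chain size alone does not account for compound 4. The value of compound 4 is a limit, not a number, and compound 2 shares it: the limit of > 300 mg/kg in this assay, at which 2 of the 4 values shown sit.

Going by these compounds, the true size of the step stays open. So does whether branching on the carbon attached to the ring matters, which isopropyl or cyclopropyl at this position would address.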